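The source may hold more compounds than are shown below. What is called first, only, known or untested is meant among the compounds shown, and "the series" means these compounds.

Measured compounds:
compound 1 `Cc1cncc(-c2ccc3[nH]c(=O)nc(-c4ccccc4)c3c2)c1` — in an ADME assay on THP-1 cells (Homo sapiens) for cytotoxicity, read by MTT assay, with a stated time of 72 h (a lower number here means that less compound is needed, a higher number that more compound is needed for the effect), compound 1 gives > 50000 nM, a limit.
compound 2 `O=c1nc(-c2ccccc2)c2cc(-c3cc[nH]n3)ccc2[nH]1` — in this assay compound 2 gives > 50000 nM, a limit.
compound 3 `Cc1ccccc1-c1nc(=O)[nH]c2ccc(-c3cc[nH]n3)cc12` — in this assay compound 3 gives > 50000 nM, a limit.

Compound 3 thus stands at the limit of this assay, and no measured value in the series sits anywhere else. The step that the two limits leave unreadable from compound 1 to compound 2 and the step that the two limits leave unreadable from compound 2 to compound 3 are both unreadable between limits, so neither gives a size that bears on the next change. Compound 4 `COc1ccccc1-c1nc(=O)[nH]c2ccc(-c3cc[nH]n3)cc12` differs from compound 3 in one place: methoxy in place of methyl on an aromatic carbon. Given (the limit of > 50000 nM in this assay, at which 3 of the 3 values shown sit), no readable step in either direction is available, and nothing beyond the scatter is expected. Compound 4 is therefore expected to stay at the limit, estimated at 50000 nM with a range of 20000 nM to 100000 nM, an expected step of a number no higher from compound 3 to compound 4 (the limit leaves the size open).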

Compound 4, half-maximal effective concentration: > 50000 nM
Compound 4 ended at the assay's limit; the forecaster's own chance of this, stated with the estimate: 85%; the middle value sits exactly at the limit.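

The steps from compound 2 and from compound 3 to compound 4 cannot be read, as all these values are limits: the limit of > 50000 nM in this assay, at which 4 of the 4 values shown sit. The compounds shown leave open whether any change to the shared core gives a measurable value in this assay.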